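Compound 4 After Three Compounds Without Inhibition

The compounds below may be only part of what the source reports. "The series", "measured", "known", "first", "only" and "open" are said of these compounds alone.

The compounds measured so far:
compound 1, `Nc1scc(CN2CCN(c3ccc(Cl)cc3Cl)CC2)c1C(=O)c1ccc(Cl)cc1`: 0%
compound 2, `Nc1scc(CN2CCN(c3ccc(F)cc3Cl)CC2)c1C(=O)c1ccc(Cl)cc1`: 0%
compound 3, `Nc1scc(CN2CCN(CCCc3ccc(Cl)cc3)CC2)c1C(=O)c1ccc(Cl)cc1`: 0%

All three share one core and differ only in the group on the ring nitrogen and in one halogen. In an assay on CHO cells for displacement of a labelled ligand from adenosine receptor A1 (Homo sapiens), read by scintillation counting, with a stated time of 120 min, tested at 10 uM (a lower number here means less inhibition, a higher number more inhibition at the concentration tested (going by the name of the read-out)), compound 3 gives 0%, level with compound 1 and compound 2 within the scatter. The step of no change at the digits printed from compound 1 to compound 2 (within the scatter) puts fluoro in place of chloro on an aromatic carbon. The steps of no change at the digits printed from compound 1 to compound 3 (within the scatter) and no change at the digits printed from compound 2 to compound 3 (within the scatter) replace an aryl group on the ring nitrogen with 3-(4-chlorophenyl)propyl. None of these steps moved the read-out.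

Compound 4, `Nc1scc(CN2CCN(c3ccccc3Cl)CC2)c1C(=O)c1ccc(Cl)cc1`, differs from compound 3 by 2-chlorophenyl in place of 3-(4-chlorophenyl)propyl on an amine nitrogen in a ring. This returns an aryl group directly to the ring nitrogen, as in compounds 1 and 2, which showed no inhibition either. Because no change at the digits printed from compound 1 to compound 3 (within the scatter) and no change at the digits printed from compound 2 to compound 3 (within the scatter) showed no change, the step is expected to be no change at the digits printed from compound 3 to compound 4 (within the scatter), nothing beyond the scatter. Compound 4 is therefore estimated at 0%, within -10% to 12%.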

Compound 4, a percentage reported as inhibition, at one concentration (the size of the read-out at that concentration, not a potency): 2%
Beside the measured number, compound 4's estimate is 2 percentage points below it; low and high end bracket the measured number.
By their numbers in this assay, from the lowest: compounds 1, 2, 3 and 4 (each within the scatter of the next).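

On the amine nitrogen in the ring, 2-chlorophenyl in place of 3-(4-chlorophenyl)propyl gives a number 2 percentage points higher from compound 3 to compound 4 (within the scatter) in this assay and so adds a third kind of group at this position without a read-out beyond the scatter. On the aromatic ring of that group, hydrogen in place of fluoro gives a number 2 percentage points higher from compound 2 to compound 4 (within the scatter) and hydrogen in place of chloro gives a number 2 percentage points higher from compound 1 to compound 4 (within the scatter) and so shows that taking this halogen away, not just exchanging it for another, also leaves the read-out within the scatter. No supporting data are available to explain these results.

Every group shown on this nitrogen still holds a chlorophenyl ring, which leaves open what a carboxylic acid or an amine on a longer chain would give there. Going by these compounds, the effect of any change to the shared core also remains unknown.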